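This account rests on a few compounds, and the source may have more. Where it says the series, first, only, none or still open, it means among the compounds named here.

Three compounds share one core and differ only in a single group on it: compound 1 `Cc1cc(=O)oc2cc(OCCCn3cc(CNC(=O)CCCCC4CCSS4)nn3)ccc12`, compound 2 `CC(=O)c1cc2ccc(OCCCn3cc(CNC(=O)CCCCC4CCSS4)nn3)cc2oc1=O` and compound 3 `CCOC(=O)c1cc2ccc(OCCCn3cc(CNC(=O)CCCCC4CCSS4)nn3)cc2oc1=O`. In a functional assay on PC-12 cells (Rattus norvegicus) for cytotoxicity, read by MTT assay, with stated times of 3 h and 2 h, tested at 0.1 uM (a higher number here means a stronger effect of the compound at the concentration tested, a lower number a weaker effect), compound 1 gives 44.8%, compound 2 gives 34.6% and compound 3 gives 28%. Compound 2 stands second highest of the three numbers; nearest to it is compound 3, within the scatter, and furthest is compound 1, beyond the scatter.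

Compound 4 `O=C(CCCCC1CCSS1)NCc1cn(CCCOc2ccc3cc(C(=O)O)c(=O)oc3c2)nn1` is not yet measured. It differs from compound 2 by hydroxy in place of methyl on a carbonyl carbon. For the measured compounds named here, the only measured step that bears on this change sits at the same carbonyl carbon: a number 6.6 percentage points lower from compound 2 to compound 3 (within the scatter). That swap of one group on the carbonyl carbon left the read-out essentially where it was, and nothing else in the data speaks to a hydroxy at this place. A step of similar size is therefore expected, that is, none beyond the scatter, giving a number 4.6 percentage points lower from compound 2 to compound 4 (within the scatter) as the estimated change. Compound 4 is thus expected to give about 30%, with a likely range from 17% to 43%.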

Compound 4, a percentage reported as activity, at one concentration (the size of the read-out at that concentration, not a potency): 43.4%
Estimate against measurement, compound 4: 13.4 percentage points below; measured number outside the range, above it.
By their numbers in this assay, from the lowest: compounds 3, 2, 4 and 1 (each within the scatter of the next, the first and the last beyond it).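

In this assay, hydroxy in place of methyl on a carbonyl carbon gives a number 8.8 percentage points higher from compound 2 to compound 4 (within the scatter), so acetyl and carboxy cannot be told apart here. Hydrogen in place of ethyl on an oxygen next to a carbonyl group gives a number 15.4 percentage points higher from compound 3 to compound 4 (beyond the scatter), the first step at this place to go beyond the scatter, which shows that this group can change the read-out even though the step between compound 2 and compound 3 did not. Nothing available explains why this small change separates compound 3 from compound 4.

As far as these compounds go, whether an amine on this carbonyl carbon, forming an amide, or a longer chain on the ester oxygen would follow compound 3 or compound 4 remains open. Also open, from the compounds shown here alone, is whether the gap between these two compounds holds at other concentrations.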